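Nitro to nitrile on two related cores in trachea

This account rests on a few compounds, and the source may have more. Where it says the series, first, only, none or still open, it means among the compounds named here.

Measured compounds:
compound 1 `CC1(C)c2ccc([N+](=O)[O-])cc2[C@@H](n2ccccc2=O)[C@@H]1O` gives 150 nM in a functional assay (trachea) for inhibition, with Cavia porcellus as the target; on this read-out higher numbers stand for weaker inhibition and lower numbers for stronger inhibition
compound 2 `CC1(C)c2ccc(C#N)cc2[C@@H](n2ccccc2=O)[C@@H]1O` gives 1940 nM in this assay
compound 3 `CC1(C)C=C(n2ccccc2=O)c2cc([N+](=O)[O-])ccc21` gives 840 nM in this assay

Compound 1 and compound 2 share a core and differ only in one place: cyano in place of nitro on an aromatic carbon. That single change gave a 13-fold higher number from compound 1 to compound 2 (1.11 log units; beyond the scatter) in this assay, a step well beyond the usual scatter. Compound 3 carries the nitro group on a different core; how its core differs from that of compound 1 is not broken down here. Its value in this assay lies between the other two, a higher number than compound 1 and a lower number than compound 2, both gaps beyond the scatter.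

Compound 4 `CC1(C)C=C(n2ccccc2=O)c2cc(C#N)ccc21` has not yet been measured. It stands to compound 3 exactly as compound 2 stands to compound 1: cyano in place of nitro on an aromatic carbon. The place of the change reads the same in both pairs, so this is the same change, made a second time on a second core. For the measured compounds named here, only one earlier instance exists, so how far the step carries over is uncertain. The expected step, of similar direction and size to the first, is estimated as an 11-fold higher number from compound 3 to compound 4 (1.03 log units; beyond the scatter), because the first instance gave a 13-fold higher number from compound 1 to compound 2 (1.11 log units; beyond the scatter). On that basis compound 4 is estimated at 9000 nM in this assay, with a likely range from 2500 nM to 30000 nM.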

Compound 4, half-maximal inhibitory concentration: 5260 nM
Compound 4: the middle estimate sits 1.7-fold (0.23 log units) above what was measured, within the range that was stated.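

Putting cyano in place of nitro on the second core again gave a higher number in this assay, a 6.3-fold higher number from compound 3 to compound 4 (0.80 log units; beyond the scatter), so on both cores the nitrile is the weaker inhibitor of its pair. The two steps run the same way, and the gap between them gives no ground for saying that the change costs more on one core than on the other: the same change on two cores in this assay, a 13-fold higher number (1.11 log units; beyond the scatter) from compound 1 to compound 2 and a 6.3-fold higher number (0.80 log units; beyond the scatter) from compound 3 to compound 4, 2.1-fold (0.32 log units) apart, within the scatter of two such steps. This shows that the step carried over between these two cores, but two pairs cannot show that it would hold on any further core, and they give no reason why the nitrile pairs with weaker inhibition.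

On these data alone, what remains open is how other groups on the same aromatic carbon, such as trifluoromethyl, an amine or a carboxylic acid, would compare with nitro and cyano on either core in this assay. Also open, as far as these compounds go, is whether the same step would appear with the change made on another carbon of the aromatic ring, since both pairs here carry it in the same place.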